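A few compounds are considered here, and "the series" means these few. Any claim that something is new, unique, unknown or untested is made for them only; others in the source may bear on it.

In a functional assay on MCF7 cells (Homo sapiens) for antiproliferative activity, read by MTT assay, with a stated time of 72 h (a higher number here means a weaker inhibitor, a lower number a stronger inhibitor), compound 1 `CNc1nc(-c2cc(OC)c(OC)c(OC)c2)c(-c2ccc(C(F)(F)F)cc2)s1` gives 7290 nM, while compound 2 `CNc1nc(-c2cc(OC)c(OC)c(OC)c2)c(-c2ccc(OC)cc2)s1` gives 37.6 nM, the lower of the two numbers. Compound 3 `COc1ccc(-c2sc(C)nc2-c2cc(OC)c(OC)c(OC)c2)cc1` replaces one group of compound 2, with methyl in place of methylamino on an aromatic carbon. Within the data shown here, the only measured step, a 190-fold lower number from compound 1 to compound 2 (2.29 log units; beyond the scatter), is large but lies at a different place, so it shows only that one swap can move the number far. No measurement tests this place directly, so the direction is a judgement. A moderate rise is expected, an 8.0-fold higher number from compound 2 to compound 3 (0.90 log units; beyond the scatter). Compound 3 is estimated at 300 nM, with an expected range of 40 nM to 2500 nM.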

Compound 3, half-maximal inhibitory concentration: 606 nM
Beside the measured number, compound 3's estimate is 2.0-fold (0.31 log units) below it; measured number inside the range.
By their numbers in this assay, from the lowest: compound 2; then compound 3; then compound 1.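

In this assay, methyl in place of methylamino on the aromatic carbon next to the ring nitrogen and next to the ring sulfur brings a 16-fold higher number from compound 2 to compound 3 (1.21 log units; beyond the scatter) and shows that this place, like the one changed earlier, can move the number far. Of these two groups, methylamino gives the stronger inhibitor on the shared core. The swap removes the nitrogen and the hydrogen-bond donor together, so their shares cannot be separated. Going by these compounds, whether a plain amine or an ethylamino group would match methylamino here stays open. Nothing measured on these compounds explains the rise.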